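This account rests on a few compounds, and the source may have more. Where it says the series, first, only, none or still open, it means among the compounds named here.

Measured so far in a functional assay on A549 cells (Homo sapiens) for cytotoxicity, read by MTT assay, with a stated time of 72 h; a lower number here means a stronger inhibitor, a higher number a weaker inhibitor:
compound 1 `COc1ncc(-c2ccc3nc(NC(=O)N(C)C)nn3c2)cc1NS(=O)(=O)c1ccc(F)cc1`, 1190 nM
compound 2 `COc1ncc(-c2ccc3nc(NC(=O)NCC(=O)N4CCCC4)nn3c2)cc1NS(=O)(=O)c1ccc(F)cc1`, 2190 nM
compound 3 `CCN(CC)CCNC(=O)Nc1nc2ccc(-c3cnc(OC)c(NS(=O)(=O)c4ccc(C)cc4)c3)cn2n1`, 730 nM

Compound 3 has the lowest of the three numbers in this assay. Its gap to compound 1 lies within the scatter, so those two cannot be ordered against each other; its gap to compound 2 lies beyond the scatter. Going by the values given here, the only measured step between compounds that differ in one place, a 1.8-fold higher number from compound 1 to compound 2 (0.26 log units; within the scatter), concerns the group on a carbonyl carbon and stays within the scatter.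

Compound 4 `CCN(CC)CCNC(=O)Nc1nc2ccc(-c3cnc(OC)c(NS(=O)(=O)c4ccc(Cl)cc4)c3)cn2n1` differs from compound 3 in one place: chloro in place of methyl on an aromatic carbon. Among the compounds with values here, no measured step touches this position, so the step from compound 1 to compound 2 offers no direct guide, and the sulfonyl-bearing aryl ring is otherwise unexplored among the three measured compounds. With nothing in the data pointing to a shift at this site, the expectation for this assay is a step no larger than the scatter, in no preferred direction. The expected step is a 1.1-fold higher number from compound 3 to compound 4 (0.04 log units; within the scatter). For compound 4 the estimate in this assay is 800 nM, with a range from 350 nM to 1800 nM.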

Compound 4, half-maximal inhibitory concentration: 680 nM
Estimate against measurement, compound 4: 1.2-fold (0.07 log units) above; measured number inside the range.
By their numbers in this assay, from the lowest: compounds 4, 3, 1 and 2 (each within the scatter of the next, the first and the last beyond it).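

In this assay, going by these compounds alone, a 1.1-fold lower number from compound 3 to compound 4 (0.03 log units; within the scatter) is the first measured step at this position, on the aromatic carbon para to a large group, whereas the earlier step concerned only the group on a carbonyl carbon. The step lies within the scatter, so compound 3 and compound 4 cannot be ordered, and with the rest of the molecule held the same, 4-methylphenyl and 4-chlorophenyl on the sulfonyl group cannot be told apart in this read-out. No supporting evidence bears on this result, so the data offer no explanation for it.

Within the data shown here, this single exchange covers only two groups of similar heavy-atom count, so it leaves open whether a group such as an amine, a carboxylic acid or a longer alkyl chain at this place would give a step beyond the scatter. It also leaves open whether methyl and chloro would stay this close with another group on the carbonyl carbon, such as the dimethylamino of compound 1, since only one exchange at this position is shown.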